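Chain oxygen to carbon in a fluorophenylsulfonamide series

The source may hold more compounds than are shown below. What is called first, only, known or untested is meant among the compounds shown, and "the series" means these compounds.

Measured so far:
compound 1 `O=C(O)CC/C=C\C[C@@H]1[C@@H](CNS(=O)(=O)c2ccc(F)cc2)CC[C@H]1F`, in a functional assay on a cell-free system (plasma) for inhibition of thromboxane A2 receptor (Homo sapiens), read by turbidimetry (a lower number here means a stronger inhibitor, a higher number a weaker inhibitor), compound 1 gives 1900 nM; 1900 nM; 650 nM (3 entries)
compound 2 `O=C(O)COCCCC[C@@H]1[C@@H](CNS(=O)(=O)c2ccc(F)cc2)CC[C@H]1F`, in this assay compound 2 gives 650 nM

Going by the values given here, compound 2 stands at the only number it has in this assay, and the repeated entries of compound 1 the several entries of compound 1 in this assay, 1900 nM; 1900 nM; 650 nM (3 entries) show how far entries of one compound can drift. Compound 3 `O=C(O)CCCCCC[C@@H]1[C@@H](CNS(=O)(=O)c2ccc(F)cc2)CC[C@H]1F` carries the change (2-carboxyethyl in place of carboxymethoxy on a saturated chain carbon, four bonds along the chain from a saturated ring carbon), 2-carboxyethyl in place of carboxymethoxy on a saturated chain carbon, four bonds along the chain from a saturated ring carbon. Among the compounds with values here, no step between measured compounds bears on this change. For compound 3 the expected step of a 1.2-fold higher number from compound 2 to compound 3 (0.09 log units; within the scatter) is none beyond the scatter. Compound 3 is estimated at 800 nM, between 300 nM and 2500 nM.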

Compound 3, half-maximal inhibitory concentration: 6000 nM
Compound 3: middle estimate off by 7.5-fold (0.88 log units), on the low side; measured number above the stated range.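

In this assay the change from carboxymethoxy to 2-carboxyethyl at this chain position is not neutral, with a 9.2-fold higher number from compound 2 to compound 3 (0.97 log units; beyond the scatter) as the first step read in the series. Replacing the chain oxygen with carbon therefore moves the number the wrong way, although compound 2 rests on a single entry. The step is also wider than the drift within one compound: the several entries of compound 1 in this assay, 1900 nM; 1900 nM; 650 nM (3 entries).

Still open, on these data alone, is whether a sulfur atom or an amide at the same chain place would track compound 2 or compound 3. A longer ether chain ending in the carboxylic acid is equally unresolved.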